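This account rests on a few compounds, and the source may have more. Where it says the series, first, only, none or still open, it means among the compounds named here.

Measured compounds:
compound 1 `O=C(N/N=C/c1ccc(F)cc1Cl)Nc1cc2c(Nc3ccc(F)c(Cl)c3)ncnc2cc1O[C@H]1CCOC1`: 26100 nM
compound 2 `CCN(CC)c1ccc(/C=N/NC(=O)Nc2cc3c(Nc4ccc(F)c(Cl)c4)ncnc3cc2O[C@H]2CCOC2)c(O)c1`: 15700 nM
compound 3 `COc1cc2ncnc(Nc3ccc(F)c(Cl)c3)c2cc1NC(=O)N/N=C/c1ccc(F)cc1Cl`: 29200 nM

All three were run in a functional assay on HepG2 cells (Homo sapiens) for cytotoxicity, read by MTT assay, with a stated time of 72 h; a lower number here means a stronger inhibitor, a higher number a weaker inhibitor. Compound 3 gives the highest of the three numbers, but its gaps to compound 1 and to compound 2 both lie within the scatter, so no order among the three can be read. Compound 4 `COc1cc2ncnc(Nc3ccc(F)c(Cl)c3)c2cc1NC(=O)N/N=C/c1ccc(O)cc1` differs from compound 3 in one place: 4-hydroxyphenyl in place of 2-chloro-4-fluorophenyl on a carbon with a double bond to nitrogen. Among the compounds with values here, the only measured step at that same carbon, a 1.7-fold lower number from compound 1 to compound 2 (0.22 log units; within the scatter), stayed within the scatter, and the step of a 1.1-fold higher number from compound 1 to compound 3 (0.05 log units; within the scatter) at the oxygen on the aromatic ring did likewise. No step beyond the scatter is therefore expected in this assay from compound 3 to compound 4. Compound 4 is expected to give 25000 nM, between 10000 nM and 60000 nM, an estimated step of a 1.2-fold lower number from compound 3 to compound 4 (0.07 log units; within the scatter).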

Compound 4, half-maximal inhibitory concentration: 26300 nM
Beside the measured number, compound 4's estimate is 1.1-fold (0.02 log units) below it; measured number inside the range.
By their numbers in this assay, from the lowest: compounds 2, 1, 4 and 3 (each within the scatter of the next).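

In this assay, 4-hydroxyphenyl in place of 2-chloro-4-fluorophenyl on the carbon with a double bond to nitrogen gives a 1.1-fold lower number from compound 3 to compound 4 (0.05 log units; within the scatter) on the methyl ether core. This position therefore takes a second replacement within the scatter, here with both halogens gone and a hydrogen-bond donor present. No measured evidence bears on the reason for this result. Still open, going by these compounds, is whether an amine or a carboxylic acid on that phenyl ring, or a longer chain in place of the ring, would leave the number within the scatter.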